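Chloro to methoxy: expected step for compound 4

A few compounds are considered here, and "the series" means these few. Any claim that something is new, unique, unknown or untested is made for them only; others in the source may bear on it.

Measured in a functional assay on MDA-MB-231 cells (Homo sapiens) for antiproliferative activity, read by MTT assay, with a stated time of 72 h; on this read-out higher numbers stand for weaker inhibition and lower numbers for stronger inhibition:
compound 1 `O=C(CCc1cccc2c1B(O)OC2)Nc1ccccc1` gives 230 nM
compound 2 `O=C(CCc1cccc2c1B(O)OC2)Nc1cccc(-c2ccccc2)c1` gives 220 nM
compound 3 `O=C(CCc1cccc2c1B(O)OC2)Nc1cccc(-c2ccc(Cl)cc2)c1` gives 260 nM

Compound 3 stands within the scatter of the other two, with a 1.1-fold higher number from compound 1 to compound 3 (0.05 log units; within the scatter) as the step from the unsubstituted end of the series. Compound 4 `COc1ccc(-c2cccc(NC(=O)CCc3cccc4c3B(O)OC4)c2)cc1` carries methoxy in place of chloro on an aromatic carbon, para to a large group methoxy in place of chloro on an aromatic carbon and so reads as 4-chlorophenyl to 4-methoxyphenyl. Going by the values given here, two measured steps bear on it: a 1.2-fold higher number from compound 2 to compound 3 (0.07 log units; within the scatter) for chloro in place of hydrogen and a 1.0-fold lower number from compound 1 to compound 2 (0.02 log units; within the scatter) for phenyl in place of hydrogen, both within the scatter. Among the compounds with values here, no measured compound carries methoxy. In this assay no step beyond the scatter is expected. The estimated size is a 1.1-fold lower number from compound 3 to compound 4 (0.03 log units; within the scatter) and thus none beyond the scatter. Compound 4 is expected at 240 nM within an estimated 130 nM to 440 nM range.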

Compound 4, half-maximal inhibitory concentration: 88 nM
Estimate against measurement, compound 4: 2.7-fold (0.44 log units) above; the whole stated range lies above it.
By their numbers in this assay, from the lowest: compound 4; then compounds 2, 1 and 3 (each within the scatter of the next).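

At this position the group matters: hydrogen and chloro stay within the scatter of each other, yet methoxy gives a 3.0-fold lower number from compound 3 to compound 4 (0.47 log units; beyond the scatter) and also a 2.5-fold lower number from compound 2 to compound 4 (0.40 log units; beyond the scatter) as the step from the phenyl compound. The 4-methoxyphenyl group, with a 2.6-fold lower number from compound 1 to compound 4 (0.42 log units; beyond the scatter) from the unsubstituted end of the series, is the only group shown that moves the number beyond the scatter. No measurement at hand explains this step.

From the compounds shown here alone, whether the step is particular to methoxy or extends to hydroxy, ethoxy or dimethylamino on this carbon stays open.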